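The compounds below may be only part of what the source reports. "The series", "measured", "known", "first", "only" and "open" are said of these compounds alone.

Measured in an assay on membranes from striatum (strain Sprague-Dawley) for displacement of a labelled ligand from sodium-dependent dopamine transporter (Rattus norvegicus), read by scintillation counting, with a stated time of 120 min; on this read-out higher numbers stand for weaker inhibition and lower numbers for stronger inhibition:

compound 1, `Fc1ccc(C(SCCNC2CCN(Cc3ccccc3)CC2)c2ccc(F)cc2)cc1`, gives 32.9 nM
compound 2, `Fc1ccc(CN2CCC(NCCSC(c3ccc(F)cc3)c3ccc(F)cc3)CC2)cc1`, gives 25.5 nM
compound 3, `O=C(c1ccccc1)N1CCC(NCC[S+]([O-])C(c2ccc(F)cc2)c2ccc(F)cc2)CC1`, gives 79.1 nM

Compounds 1 and 2 share a core and differ in one place: fluoro in place of hydrogen on an aromatic carbon. This change gave a 1.3-fold lower number from compound 1 to compound 2 (0.11 log units; within the scatter), so the two numbers cannot be told apart. Compound 3 has a different core; how its core differs from that of compound 1 is not broken down here. Compound 3 has the highest number of the three in this assay, and its gap to compound 1 and to compound 2 lies beyond the usual scatter.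

Compound 4, `O=C(c1ccc(F)cc1)N1CCC(NCC[S+]([O-])C(c2ccc(F)cc2)c2ccc(F)cc2)CC1`, is not yet measured. It differs from compound 3 by the same change: fluoro in place of hydrogen on an aromatic carbon. The place of the new fluorine is the same as between compound 1 and compound 2, so the same kind of step is expected. Because the earlier change gave a 1.3-fold lower number from compound 1 to compound 2 (0.11 log units; within the scatter), the step from compound 3 to compound 4 is expected to be a 1.2-fold lower number from compound 3 to compound 4 (0.09 log units; within the scatter). On this basis compound 4 is estimated at 65 nM, between 30 nM and 150 nM.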

Compound 4, inhibition constant: 77.2 nM
Beside the measured number, compound 4's estimate is 1.2-fold (0.07 log units) below it; the range from low to high includes it.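

In this assay, placing fluoro on the benzoyl ring of compound 3 gave a 1.0-fold lower number from compound 3 to compound 4 (0.01 log units; within the scatter), so the two numbers cannot be told apart. The earlier step on the other core was also within the scatter, and the two steps do not differ by more than the scatter allows: the same change on two cores in this assay, a 1.3-fold lower number (0.11 log units; within the scatter) from compound 1 to compound 2 and a 1.0-fold lower number (0.01 log units; within the scatter) from compound 3 to compound 4, 1.3-fold (0.10 log units) apart, within the scatter of two such steps. This shows that, on these two cores, phenyl to 4-fluorophenyl leaves the number in this assay within the usual scatter, but it does not show that the change has a real effect of any set size, nor that the same would hold on a third core.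

The compounds shown leave open whether another group in place of that hydrogen, such as chloro, methoxy or a carboxylic acid, would move the number beyond the scatter. They also leave open whether the fluoro step would stay this small on a core with a longer chain.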